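Carbonyl substituent changes on the shared core: oxygen to sulfur

A few compounds are considered here, and "the series" means these few. Any claim that something is new, unique, unknown or untested is made for them only; others in the source may bear on it.

Measured compounds:
- compound 1 `CC(C)OC(=O)N1CCC(Oc2ncnc3c2CCN3c2ccc(S(C)(=O)=O)cc2F)CC1`: 50.1 nM
- compound 2 `CCCCOC(=O)N1CCC(Oc2ncnc3c2CCN3c2ccc(S(C)(=O)=O)cc2F)CC1`: 50.1 nM
- compound 3 `COCCOC(=O)N1CCC(Oc2ncnc3c2CCN3c2ccc(S(C)(=O)=O)cc2F)CC1`: 316 nM

Three compounds of the series have been run in a functional assay on CHO-K1 cells for agonist activity at Glucose-dependent insulinotropic receptor (Homo sapiens), read by a luciferase reporter, with a stated time of 5 h; a lower number here means that less compound is needed, a higher number that more compound is needed for the effect. Compound 1 stands level with compound 2 at the digits given, and together the two hold the lowest numbers of the three; the step of no change at the digits printed from compound 1 to compound 2 (within the scatter) is within the scatter, so no order between them is claimed. Compound 3 sits apart: a 6.3-fold higher number from compound 1 to compound 3 (0.80 log units; beyond the scatter) and a 6.3-fold higher number from compound 2 to compound 3 (0.80 log units; beyond the scatter) are both beyond the scatter, in the direction of more compound needed.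

Compound 4 `CC(C)SC(=O)N1CCC(Oc2ncnc3c2CCN3c2ccc(S(C)(=O)=O)cc2F)CC1` is not yet measured. The change from compound 1 is isopropylsulfanyl in place of isopropoxy on a carbonyl carbon. Within the data shown here, no measured step touches this place: the steps so far alter only the group on an oxygen next to a carbonyl group, leaving that oxygen in place, and they show that butyl in place of isopropyl leaves the number unchanged while 2-methoxyethyl in place of isopropyl raises it modestly. The change to compound 4 swaps the oxygen itself for sulfur, keeping the isopropyl. Among the measured compounds shown here, with no direct precedent, the expectation for this assay is a step of a 1.3-fold higher number from compound 1 to compound 4 (0.10 log units; within the scatter), that is, no change beyond the scatter, with the range widened for the untested swap.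

Compound 4 is therefore estimated at 63 nM, with a range from 25 nM to 160 nM.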

Compound 4, half-maximal effective concentration: 10 nM
Compound 4: the middle estimate sits 6.3-fold (0.80 log units) above what was measured, and the stated range ends above it.
By their numbers in this assay, from the lowest: compound 4; then compounds 1 and 2 (each within the scatter of the next); then compound 3.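

In this assay, among these compounds, this position responds to the atom attached to the carbonyl carbon, not only to the group carried on that atom: isopropylsulfanyl in place of isopropoxy, with the isopropyl kept, gives a 5.0-fold lower number from compound 1 to compound 4 (0.70 log units; beyond the scatter), whereas the earlier steps varied only the group on the oxygen and none lowered the number. Compound 4 also stands apart from the other two compounds, with a 5.0-fold lower number from compound 2 to compound 4 (0.70 log units; beyond the scatter) and a 32-fold lower number from compound 3 to compound 4 (1.50 log units; beyond the scatter), so its number is the lowest of the four, although these two steps change the chain as well as the atom. The data shown offer no measured basis for explaining this gain.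

On these data alone, it remains open whether butylsulfanyl and 2-methoxyethylsulfanyl would follow the order of their oxygen counterparts, or whether the methoxy-bearing chain would raise the number on sulfur as it does on oxygen. Also open, as far as these compounds go, is how an isopropylamino group on the same carbonyl carbon, or a longer branched chain on the sulfur, would compare with isopropylsulfanyl.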